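Adding an Isopropyl Group to a Triazole Dithiocarbamate

The source may report more compounds than this note shows. Statements on the series, on what has been measured and on what is new or still open speak of the compounds shown alone.

Compound 3 `Cc1ccc(Cn2cc(CSC(=S)N3CCN(C(N)=O)CC3)nn2)cc1` stands at a limit in a functional assay on EC9706 cells (Homo sapiens) for cytotoxicity, read by MTT assay, with a stated time of 72 h; on this read-out lower numbers stand for stronger inhibition and higher numbers for weaker inhibition: compound 3 gives > 128000 nM, which is the edge of what the assay reports rather than a measured number. Compound 4 `Cc1ccc(Cn2cc(CSC(=S)N3CCN(C(=O)NC(C)C)CC3)nn2)cc1` differs from it by isopropyl in place of hydrogen on an amide-type nitrogen. Two other compounds already carry this isopropylcarbamoyl group: in this assay compound 1 `CC(C)NC(=O)N1CCN(C(=S)SCc2cn(Cc3ccccc3F)nn2)CC1` gives 20800 nM and compound 2 `CC(C)NC(=O)N1CCN(C(=S)SCc2cn(Cc3ccc(F)cc3)nn2)CC1` gives 12200 nM. Going by the values given here, the only measured step, a 1.7-fold lower number from compound 1 to compound 2 (0.23 log units; within the scatter), concerns a change elsewhere and says nothing direct about adding isopropyl. Both compounds with the isopropyl group, however, sit within the measurable range. On that basis compound 4 is expected to move by an at least 5.1-fold lower number from compound 3 to compound 4 (0.70 log units; beyond the scatter). The estimate for compound 4 is 25000 nM, between 8000 nM and 128000 nM.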

Compound 4, half-maximal inhibitory concentration: > 128000 nM
Compound 4 gave a limit, no number; the forecaster's own chance of this, stated with the estimate: 30%; at least 5.1-fold (0.70 log units) between middle value and limit.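

In this assay, isopropyl on the amide-type nitrogen does not by itself bring a measurable value: compound 4 carries it and still gives only a limit. The step from hydrogen to isopropyl cannot be read, because compound 3 and compound 4 sit at the same edge: the limit of > 128000 nM in this assay, at which 2 of the 4 values shown sit. With isopropyl kept, the aromatic group matters: methyl in place of fluoro gives an at least 10-fold higher number from compound 2 to compound 4 (1.02 log units; beyond the scatter) and 4-methylphenyl in place of 2-fluorophenyl gives an at least 6.1-fold higher number from compound 1 to compound 4 (0.78 log units; beyond the scatter).

Still open, on these data alone, is whether a chloro or methoxy group on that aromatic carbon would restore a measurable value. Also open, as far as these compounds go, is whether a longer chain than isopropyl on the amide-type nitrogen would do so.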